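Ester, aldehyde and amides on the shared core

The source may report more compounds than this note shows. Statements on the series, on what has been measured and on what is new or still open speak of the compounds shown alone.

Measured so far in a functional assay for inhibition of nuclear factor NF-kappa-B complex (Homo sapiens); on this read-out lower numbers stand for stronger inhibition and higher numbers for weaker inhibition:
- compound 1, `COc1ccc2c(c1)OC(c1cc(OC)c(OC)c(OC)c1)C(C(=O)OC(C)(C)C)=C2`, gives 14100 nM
- compound 2, `COc1ccc2c(c1)OC(c1cc(OC)c(OC)c(OC)c1)C(C=O)=C2`, gives 13500 nM
- compound 3, `CCNC(=O)C1=Cc2ccc(OC)cc2OC1c1cc(OC)c(OC)c(OC)c1`, gives only a limit, > 50000 nM

Compound 1 holds the highest of the two numbers in this assay; compound 2 lies within the scatter of it, a 1.0-fold lower number from compound 1 to compound 2 (0.02 log units; within the scatter). Compound 3 sits at the limit of > 50000 nM in this assay, at which 1 of the 3 values shown sits. The two steps toward compound 3 are the only ones beyond the scatter: an at least 3.5-fold higher number from compound 1 to compound 3 (0.54 log units; beyond the scatter) and an at least 3.7-fold higher number from compound 2 to compound 3 (0.56 log units; beyond the scatter).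

Compound 4, `COc1ccc2c(c1)OC(c1cc(OC)c(OC)c(OC)c1)C(C(=O)Nc1ccccc1)=C2`, is built from compound 1 by a change on the same carbonyl carbon, (anilino in place of tert-butoxy on a carbonyl carbon). Both measured steps that introduce a nitrogen at this carbon, an at least 3.5-fold higher number from compound 1 to compound 3 (0.54 log units; beyond the scatter) and an at least 3.7-fold higher number from compound 2 to compound 3 (0.56 log units; beyond the scatter), raised the number beyond the scatter, so a step of similar size and direction, a 3.2-fold higher number from compound 1 to compound 4 (0.50 log units; beyond the scatter), is expected for compound 4 in this assay, with a fair chance that only a limit is reported. The estimate for compound 4 is 45000 nM, within 15000 nM to 120000 nM.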

Compound 4, half-maximal inhibitory concentration: 17500 nM
Compound 4: the middle estimate sits 2.6-fold (0.41 log units) above what was measured; low and high end bracket the measured number.
By their numbers in this assay, from the lowest: compounds 2, 1 and 4 (each within the scatter of the next). At a limit, above all of these: compound 3.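

In this assay, a nitrogen on this carbonyl carbon does not by itself set an amide apart from the ester or the aldehyde: a 1.2-fold higher number from compound 1 to compound 4 (0.09 log units; within the scatter), and a 1.3-fold higher number from compound 2 to compound 4 (0.11 log units; within the scatter). What separates the two amides is the group on the amide nitrogen, with phenyl in place of ethyl: an at least 2.8-fold lower number from compound 3 to compound 4 (0.45 log units; beyond the scatter). That step starts from a limit and not from a number, since compound 3 is reported only as: the limit of > 50000 nM in this assay, at which 1 of the 4 values shown sits.

Going by these compounds, whether the phenyl ring itself matters, or any group other than ethyl on the amide nitrogen would do the same, stays open; benzyl or a longer alkyl chain there would bear on this. Also open, on these data alone, is how a carboxylic acid or a tertiary amide such as the dimethylamide on this carbonyl carbon would compare with compound 4.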